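Dechlorination on a fused purine-like core: compound 2 to 3

A few compounds are considered here, and "the series" means these few. Any claim that something is new, unique, unknown or untested is made for them only; others in the source may bear on it.

Compound 2 `ClCc1ccccc1Cn1cnc2c(Cl)nc(Cl)nc21` stands nowhere on the numbers: in a functional assay on COLO 205 cells (Homo sapiens) for cytotoxicity, read by sulforhodamine B assay, with a stated time of 48 h (on this read-out lower numbers stand for stronger inhibition of growth and higher numbers for weaker inhibition of growth), compound 2 gives "not determined" (no result reported). Compound 3 `ClCc1ccccc1Cn1cnc2c(Cl)ncnc21` differs from compound 2 by hydrogen in place of chloro on an aromatic carbon. With no number for compound 2, the step from compound 2 to compound 3 cannot be sized in this assay, in either direction. Among the compounds with values here, the only anchor is compound 1 `ClCc1ccc(Cn2cnc3c(Cl)ncnc32)cc1`, which shares the core of compound 3; in this assay compound 1 gives 2230 nM. Compound 3 is therefore expected near that anchor, estimated at 2500 nM with a range from 600 nM to 10000 nM.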

Compound 3, concentration for 50% growth inhibition: 3890 nM
Compound 3: the middle estimate sits 1.6-fold (0.19 log units) below what was measured; measured number inside the range.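

Within the data shown here, compound 2 has no number in this assay, and no step to compound 3 can be read. No evidence shown bears on this result. The compounds shown leave open what the chloro between two ring nitrogen atoms contributes to growth inhibition.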